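Adding a nitro group to compound 1

A few compounds are considered here, and "the series" means these few. Any claim that something is new, unique, unknown or untested is made for them only; others in the source may bear on it.

In a functional assay on SW982 cells (Homo sapiens) for inhibition, read by MTT assay, with a stated time of 72 h (a lower number here means a stronger inhibitor, a higher number a weaker inhibitor), compound 1 (`COc1cc(OC)c(OC)cc1/C=C/C(=O)c1ccccc1`) gives > 150000 nM, which is a limit of the assay and not a number. Compound 2 (`COc1cc(OC)c(OC)cc1/C=C/C(=O)c1ccc(O)cc1O`) gives 32400 nM. Among the measured compounds shown here, the one measured step, an at least 4.6-fold lower number from compound 1 to compound 2 (0.66 log units; beyond the scatter), replaces phenyl with 2,4-dihydroxyphenyl on a carbonyl carbon, and its true size remains open. Compound 3 (`COc1cc(OC)c(OC)cc1/C=C/C(=O)c1cccc([N+](=O)[O-])c1`) carries a different change: nitro in place of hydrogen on an aromatic carbon. For the measured compounds named here, no measured step tests this group, so the step to compound 2 offers only a rough guide. A modest move to a lower number in this assay is expected, and a second reading at the limit remains possible. The expected step is an at least 2.1-fold lower number from compound 1 to compound 3 (0.33 log units; beyond the scatter). Compound 3 is estimated at 70000 nM, with an expected range of 20000 nM to 200000 nM.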

Compound 3, half-maximal inhibitory concentration: 101000 nM
Compound 3: middle estimate off by 1.4-fold (0.16 log units), on the low side; low and high end bracket the measured number.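

Nitro in place of hydrogen on an aromatic carbon, meta to a large group, gives an at least 1.4-fold lower number from compound 1 to compound 3 (0.17 log units; that floor lies within the scatter). That floor alone does not establish a real change, although compound 3 gives a number where compound 1 gives only a limit. The true size of this step stays open because compound 1 stands at that limit: the limit of > 150000 nM in this assay, at which 1 of the 3 values shown sits.

With only a floor for each step, the nitro change and the 2,4-dihydroxyphenyl change cannot be ranked against each other. The compounds shown also leave open how an amine or a carboxylic acid would read in place of nitro on this same aromatic carbon, and so whether any group there moves the number clearly beyond the scatter.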